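Amino in place of chloro on the fused ring

The source may report more compounds than this note shows. Statements on the series, on what has been measured and on what is new or still open speak of the compounds shown alone.

Compound 1 `Nc1nn(C(=O)Nc2ccc(Cc3ccccc3)cc2)c2ccccc12` gives 36900 nM in a functional assay on SK-OV-3 cells (Homo sapiens) for antiproliferative activity, read by sulforhodamine B assay, with a stated time of 48 h; a lower number here means a stronger inhibitor of growth, a higher number a weaker inhibitor of growth. Compound 2 `Nc1nn(C(=O)Nc2ccc(Cc3ccccc3)cc2)c2ccc(Cl)cc12` gives 15800 nM.

Compound 2 stands lowest of the two numbers; its nearest neighbour is compound 1, reached by a 2.3-fold lower number from compound 1 to compound 2 (0.37 log units; beyond the scatter). Compound 3 `Nc1ccc2c(c1)c(N)nn2C(=O)Nc1ccc(Cc2ccccc2)cc1` differs from compound 2 by amino in place of chloro on an aromatic carbon. Within the data shown here, only that one measured step bears on this change, and it concerns the chloro that now leaves, not the amino that enters, so no measured step shows what the amino does. The number is expected to drift back toward compound 1, giving an estimated 1.6-fold higher number from compound 2 to compound 3 (0.20 log units; within the scatter) for compound 3. The estimate for compound 3 is 25000 nM, between 10000 nM and 60000 nM.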

Compound 3, concentration for 50% growth inhibition: 15300 nM
Beside the measured number, compound 3's estimate is 1.6-fold (0.21 log units) above it; low and high end bracket the measured number.
By their numbers in this assay, from the lowest: compounds 3 and 2 (each within the scatter of the next); then compound 1.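

In this assay, amino and chloro on this aromatic carbon cannot be told apart, with a 1.0-fold lower number from compound 2 to compound 3 (0.01 log units; within the scatter). Measured against hydrogen, amino therefore does what chloro did, with a 2.4-fold lower number from compound 1 to compound 3 (0.38 log units; beyond the scatter), so the modest gain at this position is no longer tied to chloro alone.

Left open is whether a hydroxyl, a methoxy or a nitrile on the same aromatic carbon would also bring the number down from that of compound 1. No evidence at hand bears on why amino and chloro read alike here.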